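Hydroxymethyl added to the 3-hydroxypropyl amide chain

The source may hold more compounds than are shown below. What is called first, only, known or untested is meant among the compounds shown, and "the series" means these compounds.

In a functional assay on MCF7 cells (Homo sapiens) for antiproliferative activity, read by MTT assay, with a stated time of 24 h (on this read-out higher numbers stand for weaker inhibition and lower numbers for stronger inhibition), compound 3 `CCn1c(C(=O)NCCCO)ccc1C(CC)(CC)c1ccc(OCS(=O)(=O)c2ccccc2)c(C)c1` gives 42000 nM and compound 2 `CCn1c(C(=O)N[C@H](CO)C(C)C)ccc1C(CC)(CC)c1ccc(OCS(=O)(=O)c2ccccc2)c(C)c1` gives 25500 nM. These two values lie within the scatter of each other, so compound 3 sits at the high end of the series together with compound 2. The 2-(diethylamino)ethyl amide compound 1 `CCN(CC)CCNC(=O)c1ccc(C(CC)(CC)c2ccc(OCS(=O)(=O)c3ccccc3)c(C)c2)n1CC` gives 4680 nM, and a 9.0-fold higher number from compound 1 to compound 3 (0.95 log units; beyond the scatter) separates it from compound 3.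

The next compound, compound 4 `CCn1c(C(=O)N[C@H](CO)CCO)ccc1C(CC)(CC)c1ccc(OCS(=O)(=O)c2ccccc2)c(C)c1`, differs from compound 3 by hydroxymethyl in place of hydrogen on a saturated chain carbon bound to an amide-type nitrogen and a saturated chain carbon. The hydroxymethyl replaces hydrogen on a saturated chain carbon bound to an amide-type nitrogen and a saturated chain carbon, so 3-hydroxypropyl becomes 3-hydroxy-1-(hydroxymethyl)propyl.

The closest evidence is the pair of hydroxyl-bearing chains. Compound 2 already carries 1-(hydroxymethyl)-2-methylpropyl, and a 1.6-fold higher number from compound 2 to compound 3 (0.22 log units; within the scatter) shows that this chain and 3-hydroxypropyl are not told apart. The larger steps, a 5.4-fold higher number from compound 1 to compound 2 (0.74 log units; beyond the scatter) and a 9.0-fold higher number from compound 1 to compound 3 (0.95 log units; beyond the scatter), both involve loss of the diethylamino group. Compound 4 lacks that group as well, so these steps say little about the present change. No data yet show a chain with two hydroxyl groups.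

No shift beyond the scatter is therefore expected in this assay. The expected change is a 1.2-fold lower number from compound 3 to compound 4 (0.08 log units; within the scatter). For compound 4 the estimated value is 35000 nM, with an expected range of 14000 nM to 80000 nM.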

Compound 4, half-maximal inhibitory concentration: 28500 nM
The estimate for compound 4 lay 1.2-fold (0.09 log units) above the measured number, and the stated range covers the measured number.
By their numbers in this assay, from the lowest: compound 1; then compounds 2, 4 and 3 (each within the scatter of the next).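

In this assay, hydroxymethyl in place of hydrogen on a saturated chain carbon bound to an amide-type nitrogen and a saturated chain carbon gives a 1.5-fold lower number from compound 3 to compound 4 (0.17 log units; within the scatter), so the series now includes a chain with two hydroxyl groups, and this chain is not told apart from 3-hydroxypropyl. The same carbon also tolerates 2-hydroxyethyl in place of isopropyl, with a 1.1-fold higher number from compound 2 to compound 4 (0.05 log units; within the scatter), so compounds 2, 3 and 4 form one group in which the hydroxyl-bearing chains on the amide-type nitrogen are not separated. Compound 1 remains apart from this group, with a 6.1-fold higher number from compound 1 to compound 4 (0.78 log units; beyond the scatter), and no measurement at hand gives a reason for that gap.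

As far as these compounds go, it remains open whether a diethylamino or other amine group carried on the 3-hydroxy-1-(hydroxymethyl)propyl chain would give numbers near that of compound 1, which would tie the gap to the amine rather than to the rest of the chain. Also open, from the compounds shown here alone, is whether a carboxylic acid or a longer hydroxyalkyl chain on the amide-type nitrogen would move the number beyond the scatter of compounds 2, 3 and 4.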